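Amide Change on a Hydroxy Core: Expectation for Compound 4

The source may hold more compounds than are shown below. What is called first, only, known or untested is meant among the compounds shown, and "the series" means these compounds.

Measured compounds in a functional assay on A-431 cells (Homo sapiens) for antiproliferative activity, read by MTT assay, with a stated time of 72 h; a lower number here means a stronger inhibitor, a higher number a weaker inhibitor:
compound 1 `COc1cc(OC)c2c(=O)n(-c3cccc(C(=O)N4CCCCC4)c3)ccc2c1` gives 15300 nM
compound 2 `COc1cc(OC)c2c(=O)n(-c3cccc(C(N)=O)c3)ccc2c1` gives 28300 nM
compound 3 `COc1cc(O)c2c(=O)n(-c3cccc(C(=O)N4CCCCC4)c3)ccc2c1` gives 2250 nM

Compound 1 and compound 2 share a core and differ in one place, (amino in place of piperidin-1-yl on a carbonyl carbon). That change gave a 1.8-fold higher number from compound 1 to compound 2 (0.27 log units; within the scatter), so the two amides cannot be ordered against each other on this evidence. Compound 3 differs from compound 1 in a different place, (hydrogen in place of methyl on an oxygen on an aromatic ring), and here the step was a 6.8-fold lower number from compound 1 to compound 3 (0.83 log units; beyond the scatter). Compound 3 thus holds the lowest number of the three measured, and compound 2 holds the highest.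

Compound 4 `COc1cc(O)c2c(=O)n(-c3cccc(C(N)=O)c3)ccc2c1` is not yet measured. It differs from compound 3 by amino in place of piperidin-1-yl on a carbonyl carbon, the same change already seen between compound 1 and compound 2, made on the same kind of carbonyl carbon and now on the core of compound 3. Going by the values given here, the only guide to its size is the earlier pair: since that change gave a 1.8-fold higher number from compound 1 to compound 2 (0.27 log units; within the scatter), the step from compound 3 to compound 4 is expected to be similar and small, a 1.8-fold higher number from compound 3 to compound 4 (0.25 log units; within the scatter). On that basis compound 4 is estimated at 4000 nM in this assay. Allowing for the usual scatter, compound 4 is expected to fall between 1800 nM and 9000 nM.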

Compound 4, half-maximal inhibitory concentration: 15200 nM
The estimate for compound 4 lay 3.8-fold (0.58 log units) below the measured number; the measured number lies above the stated range.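

In this assay, the change from piperidin-1-yl to amino on the carbonyl carbon gave a 6.8-fold higher number from compound 3 to compound 4 (0.83 log units; beyond the scatter) on the core of compound 3, so its size did not carry over unchanged from the core of compound 1: the same change on two cores in this assay, a 1.8-fold higher number (0.27 log units; within the scatter) from compound 1 to compound 2 and a 6.8-fold higher number (0.83 log units; beyond the scatter) from compound 3 to compound 4, 3.7-fold (0.56 log units) apart, beyond the scatter of two such steps. Read the other way round, hydrogen in place of methyl on an oxygen on an aromatic ring gave a 1.9-fold lower number from compound 2 to compound 4 (0.27 log units; within the scatter) in the amino amides, and this step too did not keep the size it had in the piperidin-1-yl amides: the same change on two cores in this assay, a 6.8-fold lower number (0.83 log units; beyond the scatter) from compound 1 to compound 3 and a 1.9-fold lower number (0.27 log units; within the scatter) from compound 2 to compound 4, 3.7-fold (0.56 log units) apart, beyond the scatter of two such steps. Both comparisons rest on the same four compounds, so they form a single observation that the two changes do not add independently in this assay; it does not show why, and it cannot say whether the same holds on any other core or for any other amide.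

The compounds shown leave open whether the large step on the core of compound 3 is peculiar to piperidin-1-yl or would also appear with a pyrrolidin-1-yl, morpholin-4-yl or dimethylamino group on the carbonyl carbon. They also leave open how a carboxylic acid in place of the amide would behave on either core.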